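The source may hold more compounds than are shown below. What is called first, only, known or untested is meant among the compounds shown, and "the series" means these compounds.

Measured in a functional assay on PC-3 cells (Homo sapiens) for cytotoxicity, read by MTT assay, with a stated time of 72 h; on this read-out lower numbers stand for stronger inhibition and higher numbers for weaker inhibition:
compound 1 `CNC(=O)c1cc(Oc2ccc(C(=O)/C=C/c3ccc(Br)cc3)cc2)ccn1`: 18500 nM
compound 2 `CNC(=O)c1cc(Oc2ccc(C(=O)/C=C/c3ccc([N+](=O)[O-])cc3)cc2)ccn1`: 11100 nM
compound 3 `CNC(=O)c1cc(Oc2ccc(C(=O)/C=C/c3cc(OC)c(OC)c(OC)c3)cc2)ccn1`: 3150 nM

Compound 2 sits within the scatter of compound 1, while compound 3 lies lower, beyond the scatter. The next compound, compound 4 `CNC(=O)c1cc(Oc2ccc(C(=O)/C=C/c3ccc(OC)cc3)cc2)ccn1`, differs from compound 2 as follows: methoxy in place of nitro on an aromatic carbon. This is methoxy in place of nitro on an aromatic carbon, para to a large group.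

Within the data shown here, only one measured step changes a single group at this place: a 1.7-fold lower number from compound 1 to compound 2 (0.22 log units; within the scatter). It is small and gives no firm direction. Compound 3, at 3150 nM, also carries methoxy groups, but it differs from compound 2 in more than one place, so it offers only weak support for a shift towards lower numbers. A modest move in that direction is expected in this assay, possibly no larger than the scatter.

The expected change is a 1.5-fold lower number from compound 2 to compound 4 (0.17 log units; within the scatter). For compound 4 the estimated value is 7500 nM, with an expected range of 3000 nM to 18000 nM.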

Compound 4, half-maximal inhibitory concentration: > 50000 nM
Compound 4 gave a limit, no number; the forecaster's own chance of this, stated with the estimate: 3%; middle value at least 6.6-fold (0.82 log units) away from the limit.
By their numbers in this assay, from the lowest: compound 3; then compounds 2 and 1 (each within the scatter of the next). At a limit, above all of these: compound 4.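

In this assay compound 4 gives > 50000 nM, which is a limit of the assay and not a number. Among these compounds, the group at this place is therefore not interchangeable: methoxy in place of nitro gives an at least 4.5-fold higher number from compound 2 to compound 4 (0.65 log units; beyond the scatter), and methoxy in place of bromo gives an at least 2.7-fold higher number from compound 1 to compound 4 (0.43 log units; beyond the scatter), both beyond the scatter, whereas the only earlier step here, a 1.7-fold lower number from compound 1 to compound 2 (0.22 log units; within the scatter), stayed within it. On these data alone, both new steps are bounded from one side only, so their true size is unknown: the limit of > 50000 nM in this assay, at which 1 of the 4 values shown sits.

Open, as far as these compounds go, is whether another single group at this place, such as an amine or a carboxylic acid, would give a measurable value in this assay. Also open, from the compounds shown here alone, is which methoxy group or groups matter in compound 3, which differs from compound 4 in more than one place.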